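The compounds below may be only part of what the source reports. "The series", "measured", "known", "first", "only" and "open" are said of these compounds alone.

Measured so far in a physicochemical assay for pharmacokinetics; on this read-out lower numbers stand for a shorter-lived compound and higher numbers for a longer-lived compound:
- compound 1 `Cc1ccccc1CNC(=O)N1C(=O)c2ccccc2S1(=O)=O`: 0.792 h
- compound 2 `O=C(NCc1ccccc1C(F)(F)F)N1C(=O)c2ccccc2S1(=O)=O`: 0.187 h

Of these two numbers, compound 2 has the lower, at 0.187 h. Compound 3 `COc1ccccc1CNC(=O)N1C(=O)c2ccccc2S1(=O)=O` differs from it as follows: methoxy in place of trifluoromethyl on an aromatic carbon. In short, it has methoxy in place of trifluoromethyl on an aromatic carbon. Among the compounds with values here, one measured step bears on this: a 4.2-fold lower number from compound 1 to compound 2 (0.63 log units; beyond the scatter), which brought in trifluoromethyl in place of methyl. Within the data shown here, no methoxy compound has been measured, so a rise of similar or somewhat smaller size is expected in this assay.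

The expected change is a 2.7-fold higher number from compound 2 to compound 3 (0.43 log units; beyond the scatter).

For compound 3 the estimated value is 0.5 h, with an expected range of 0.2 h to 1.2 h.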

Compound 3, half-life: 1.12 h
Compound 3: the middle estimate sits 2.2-fold (0.35 log units) below what was measured; low and high end bracket the measured number.
By their numbers in this assay, from the lowest: compound 2; then compounds 1 and 3 (each within the scatter of the next).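

In this assay, methoxy on this aromatic carbon, ortho to a large group, gives a 6.0-fold higher number from compound 2 to compound 3 (0.78 log units; beyond the scatter), so trifluoromethyl now stands apart from a second group and not from methyl alone. Methoxy in place of methyl gives a 1.4-fold higher number from compound 1 to compound 3 (0.15 log units; within the scatter), so these two cannot be told apart here, and of the three groups only trifluoromethyl stands apart. No measurement at hand accounts for this. On these data alone, whether an amine or a carboxylic acid on this carbon would read like methyl and methoxy or like trifluoromethyl stays open. So does whether trifluoromethyl would stand apart elsewhere on the ring.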